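The source may report more compounds than this note shows. Statements on the series, on what has been measured and on what is new or still open speak of the compounds shown alone.

Compound 1, `CCCS(=O)(=O)Nc1cccc2c1CCCC2c1c[nH]cn1`: < 10000 nM
Compound 2, `CCS(=O)(=O)Nc1cccc2c1CCCC2c1c[nH]cn1`: 1070 nM

Among the compounds with values here, in an assay on isolated protein for binding affinity to Alpha-1D adrenergic receptor (Rattus norvegicus), read by radioligand binding (on this read-out lower numbers stand for stronger inhibition and higher numbers for weaker inhibition), compound 2 gives 1070 nM, the only number measured here. For compound 1 the result in this assay is only a limit of the assay, < 10000 nM, not a number. Within the data shown here, the single measured step, a step that the limit leaves unreadable from compound 1 to compound 2, cannot be read because of the limit of < 10000 nM in this assay, at which 1 of the 2 values shown sits. Compound 3, `CCS(=O)(=O)Nc1cccc2c1CCCC2c1c[nH]c(C)n1`, differs from compound 2 by methyl in place of hydrogen on an aromatic carbon. Among the measured compounds shown here, no measured step touches this part of the shared core, so none bears on the change, and no shift beyond the scatter is expected in this assay. Compound 3 is therefore estimated at 1100 nM, between 350 nM and 3500 nM, an expected step of a 1.0-fold higher number from compound 2 to compound 3 (0.01 log units; within the scatter).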

Compound 3, inhibition constant: < 10000 nM
Compound 3 gave a limit, no number; the forecaster's own chance of this, stated with the estimate: 10%; the middle value does not contradict the limit.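

Within the data shown here, compound 3 gives only a limit of the assay, not a number, so no step from compound 2 to compound 3 can be read: the limit of < 10000 nM in this assay, at which 2 of the 3 values shown sit. As far as these compounds go, whether methyl in place of hydrogen on this aromatic carbon changes binding, and by how much, stays open.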